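This account rests on a few compounds, and the source may have more. Where it says the series, first, only, none or still open, it means among the compounds named here.

Of the compounds shown here, three sharing one core have been measured in an assay (strain Wistar) for displacement of a labelled ligand from adenosine receptor A1 (Rattus norvegicus), read by scintillation counting; a lower number here means a stronger inhibitor, a higher number a weaker inhibitor. Compound 1 `Nc1nc(-c2ccccc2)nc2c1nnn2Cc1ccccc1` gives 5.6 nM. Compound 2 `O=C(Nc1nc(-c2ccccc2)nc2c1nnn2Cc1ccccc1)c1ccccc1F`, carrying (2-fluorophenyl)carbonyl in place of hydrogen on a nitrogen on an aromatic ring, gives 40 nM, a step of a 7.1-fold higher number from compound 1 to compound 2 (0.85 log units; beyond the scatter). Compound 3 `COc1ccc(Cl)cc1C(=O)Nc1nc(-c2ccccc2)nc2c1nnn2Cc1ccccc1` gives 7150 nM, the highest number of the three; the steps of a 1300-fold higher number from compound 1 to compound 3 (3.11 log units; beyond the scatter) and a 180-fold higher number from compound 2 to compound 3 (2.25 log units; beyond the scatter) are both far beyond the scatter.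

Compound 4 `O=C(Nc1nc(-c2ccccc2)nc2c1nnn2Cc1ccccc1)c1ccc([N+](=O)[O-])cc1` has not yet been measured. It differs from compound 3 in one place: 4-nitrophenyl in place of 5-chloro-2-methoxyphenyl on a carbonyl carbon. The step that bears on this most directly is a 180-fold higher number from compound 2 to compound 3 (2.25 log units; beyond the scatter), which shows that changing the aryl group on the carbonyl carbon can move the number greatly. An aryl amide at this position has already given, for compound 2, 40 nM, so the 4-nitrophenyl amide is expected to fall well below compound 3, though where between the two measured amides is uncertain. The expected step is a 24-fold lower number from compound 3 to compound 4 (1.38 log units; beyond the scatter). Compound 4 is estimated at 300 nM in this assay, within a range of 30 nM to 3000 nM.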

Compound 4, inhibition constant: 24 nM
Compound 4: the middle estimate sits 13-fold (1.10 log units) above what was measured, and the stated range ends above it.
By their numbers in this assay, from the lowest: compound 1; then compounds 4 and 2 (each within the scatter of the next); then compound 3.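

In this assay, replacing 5-chloro-2-methoxyphenyl with 4-nitrophenyl on the carbonyl carbon gives a 300-fold lower number from compound 3 to compound 4 (2.47 log units; beyond the scatter) and shows that the large loss seen for compound 3 does not extend to every substituted aryl amide at this position. The step to the other aryl amide is a 1.7-fold lower number from compound 2 to compound 4 (0.22 log units; within the scatter) and leaves 4-nitrophenyl and 2-fluorophenyl indistinguishable here, so among the three amides only compound 3 stands apart. The step from the free amine is a 4.3-fold higher number from compound 1 to compound 4 (0.63 log units; beyond the scatter) and, like the modest step to compound 2, shows that an aryl carbonyl on this nitrogen can be accommodated with a limited rise in the number, while compound 3 goes against this pattern.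

Going by these compounds, whether the chlorine or the methoxy group of compound 3 goes with its high number stays open, as does how an unsubstituted benzoyl or a small acetyl group would read on this nitrogen. No evidence at hand explains these differences.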